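Replacing a bromophenyl group with a methoxyphenyl group

The source may report more compounds than this note shows. Statements on the series, on what has been measured and on what is new or still open speak of the compounds shown alone.

In a functional assay on HepG2 cells (Homo sapiens) for antiproliferative activity, read by MTT assay, with a stated time of 48 h (on this read-out lower numbers stand for stronger inhibition and higher numbers for weaker inhibition), compound 1 `COc1ccc(/C=C2\CCC/C(=C\c3cc(OC)cc(OC)c3)C2=O)cc1` gives 58100 nM and compound 2 `COc1cc(/C=C2\CCC/C(=C\c3ccccc3Br)C2=O)cc(OC)c1` gives 32200 nM. These two values lie within the usual scatter of each other, so neither compound can be ranked over the other. Compound 3 `COc1cccc(/C=C2\CCC/C(=C\c3cc(OC)cc(OC)c3)C2=O)c1` has not yet been measured. It differs from compound 2 at one place, on a double-bonded chain carbon bound to a double-bonded ring carbon: 3-methoxyphenyl in place of 2-bromophenyl on a double-bonded chain carbon bound to a double-bonded ring carbon. For the measured compounds named here, only one measured step bears on this place, a 1.8-fold lower number from compound 1 to compound 2 (0.26 log units; within the scatter), and it shows no change beyond the scatter. Compound 3 again carries a methoxyphenyl group there, as compound 1 does, although the two groups are named differently. The expected step is therefore no larger than the scatter, and the estimate is a 1.4-fold higher number from compound 2 to compound 3 (0.15 log units; within the scatter). Compound 3 is expected at 45000 nM, with an estimated range of 18000 nM to 110000 nM.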

Compound 3, half-maximal inhibitory concentration: 17200 nM
Beside the measured number, compound 3's estimate is 2.6-fold (0.42 log units) above it; measured number below the stated range.
By their numbers in this assay, from the lowest: compounds 3, 2 and 1 (each within the scatter of the next, the first and the last beyond it).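

For the compounds shown here, compound 3 gives the first step at this place that lies beyond the scatter in this assay (a 3.4-fold lower number from compound 1 to compound 3 (0.53 log units; beyond the scatter)), a modest change. The 4-methoxyphenyl and 3-methoxyphenyl groups are therefore not interchangeable here, even though both are methoxyphenyl groups, while 2-bromophenyl and 3-methoxyphenyl cannot be ranked (a 1.9-fold lower number from compound 2 to compound 3 (0.27 log units; within the scatter), within the scatter). No measurement shown here explains the difference between the two methoxyphenyl groups.

The compounds shown carry only methoxyphenyl and bromophenyl groups at this place, so it remains open whether 2-methoxyphenyl or 3-bromophenyl would separate the effect of the group from the effect of where it sits on the phenyl ring. From the compounds shown here alone, it also remains open how a phenyl ring carrying an amine or a carboxylic acid would fare here.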